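The compounds below may be only part of what the source reports. "The series", "measured", "known", "first", "only" and "open" are said of these compounds alone.

In a functional assay on PC-3 cells (Homo sapiens) for inhibition, read by MTT assay, with a stated time of 72 h (on this read-out lower numbers stand for stronger inhibition and higher numbers for weaker inhibition), compound 3 `COc1cccc(NC(=O)CSc2nc(Nc3ccccc3)c3ccccc3n2)c1` gives 11600 nM, and compound 1 `O=C(CSc1nc(Nc2ccccc2)c2ccccc2n1)Nc1ccccc1Br` gives 19800 nM while compound 2 `O=C(CSc1nc(Nc2ccccc2)c2ccccc2n1)Nc1cccc(Br)c1` gives 11400 nM; all three numbers lie within the scatter of one another, so compound 3 is neither set apart from nor ranked against them. Compound 4 `O=C(CSc1nc(Nc2ccccc2)c2ccccc2n1)Nc1ccc(Cl)cc1Cl` differs from compound 3 by 2,4-dichlorophenyl in place of 3-methoxyphenyl on an amide-type nitrogen. The steps measured so far on this same nitrogen were a 1.0-fold higher number from compound 2 to compound 3 (0.01 log units; within the scatter) and a 1.7-fold lower number from compound 1 to compound 3 (0.23 log units; within the scatter), so swapping halogen for methoxy, or moving a substituent around that ring, changed little. Two chlorines rather than one bromine or one methoxy group is a step of the same kind, so no change beyond the scatter is expected, estimated as a 1.0-fold higher number from compound 3 to compound 4 (0.01 log units; within the scatter). Compound 4 is therefore expected to give about 12000 nM, between 5000 nM and 30000 nM.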

Compound 4, half-maximal inhibitory concentration: 9110 nM
For compound 4 the middle estimate is 1.3-fold (0.12 log units) above the measured one; the range from low to high includes it.
By their numbers in this assay, from the lowest: compounds 4, 2, 3 and 1 (each within the scatter of the next, the first and the last beyond it).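

With 2,4-dichlorophenyl on the amide-type nitrogen, the number stays within the scatter of the 3-methoxyphenyl and 3-bromophenyl compounds (a 1.3-fold lower number from compound 3 to compound 4 (0.10 log units; within the scatter); a 1.3-fold lower number from compound 2 to compound 4 (0.10 log units; within the scatter)). Within the data shown here, the comparison with compound 1 gives the first step in this set beyond the scatter, though a modest one (a 2.2-fold lower number from compound 1 to compound 4 (0.34 log units; beyond the scatter)), so this position tolerates these halogen and methoxy patterns without a large shift in this assay. No measurement here explains that step. From the compounds shown here alone, all four compounds carry a substituted phenyl on this nitrogen, so the effect of an amine or carboxylic acid on that ring, or of a longer chain in its place, remains open.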